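The source may report more compounds than this note shows. Statements on the series, on what has been measured and on what is new or still open speak of the compounds shown alone.

Measured so far:
Compound 1 `COc1ccccc1-c1c(C(=O)c2cc(OC)c(OC)c(OC)c2)sc2ccccc12`: 5000 nM
Compound 2 `COc1ccc(OC)c(-c2c(C(=O)c3cc(OC)c(OC)c(OC)c3)sc3ccccc23)c1`: 10000 nM

In a functional assay on HeLa cells (Homo sapiens) for antiproliferative activity, read by MTT assay, with a stated time of 72 h (a higher number here means a weaker inhibitor, a lower number a stronger inhibitor), compound 2 gives 10000 nM, which lies within the scatter of compound 1. The next compound is compound 3 `COc1ccc(-c2c(C(=O)c3cc(OC)c(OC)c(OC)c3)sc3ccccc23)cc1C`, and the change is 4-methoxy-3-methylphenyl in place of 2,5-dimethoxyphenyl on an aromatic carbon. For the measured compounds named here, the only measured step that bears on it is a 2.0-fold higher number from compound 1 to compound 2 (0.30 log units; within the scatter). That step covers only part of this exchange and fixes no size, so the expectation rests on thin evidence. A modestly lower number is expected in this assay, as a 6.7-fold lower number from compound 2 to compound 3 (0.82 log units; beyond the scatter). Compound 3 is estimated at 1500 nM, with a range of 100 nM to 10000 nM.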

Compound 3, half-maximal inhibitory concentration: 10000 nM
The estimate for compound 3 lay 6.7-fold (0.82 log units) below the measured number; the measured number falls inside the stated range.
By their numbers in this assay, from the lowest: compounds 1, 2 and 3 (each within the scatter of the next).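

In this assay, 4-methoxy-3-methylphenyl in place of 2,5-dimethoxyphenyl gives no change at the digits printed from compound 2 to compound 3 (within the scatter), and in place of 2-methoxyphenyl it gives a 2.0-fold higher number from compound 1 to compound 3 (0.30 log units; within the scatter), so the exchange of the whole aryl group does not separate these compounds. For the compounds shown here, all three aryl groups at this position stay within the scatter of one another, including the one with a methyl group and a single methoxy group. No measurement here accounts for this result.

As far as these compounds go, whether an aminophenyl or a hydroxyphenyl group at this position would give a number apart from these remains open.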